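The source may report more compounds than this note shows. Statements on the series, on what has been measured and on what is new or still open speak of the compounds shown alone.

Measured compounds:
compound 1 `CCOCCn1c(N2CCN(C)CC2)nc2ccccc21` gives 10 nM in a functional assay on ileum for inhibition of histamine H1 receptor (Cavia porcellus); on this read-out higher numbers stand for weaker inhibition and lower numbers for stronger inhibition
compound 2 `CCCOCCn1c(N2CCN(C)CC2)nc2ccccc21` gives 20 nM in this assay
compound 3 `CCCCCCn1c(N2CCN(C)CC2)nc2ccccc21` gives 26 nM in this assay

Compound 1 holds the lowest number of the three. Its nearest neighbour is compound 2, reached by a 2.0-fold higher number from compound 1 to compound 2 (0.30 log units; within the scatter); compound 3 lies further off, reached by a 2.6-fold higher number from compound 1 to compound 3 (0.41 log units; beyond the scatter). Between those two, a 1.3-fold higher number from compound 2 to compound 3 (0.11 log units; within the scatter).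

Compound 4 `CCOCCn1c(N2CCN(c3ccccc3)CC2)nc2ccccc21` differs from compound 1 by phenyl in place of methyl on an amine nitrogen in a ring. Going by the values given here, none of the measured steps touches this position: all three alter the chain on the aromatic nitrogen, while the methylpiperazine is kept unchanged in compounds 1, 2 and 3. So there is no measured step that bears directly on the change from compound 1 to compound 4, and the expectation rests only on the size of the replacement, a phenyl in place of a methyl on the amine nitrogen. In this assay compound 4 is expected to give a step of an 8.0-fold higher number from compound 1 to compound 4 (0.90 log units; beyond the scatter), towards a higher number. The estimate for compound 4 is 80 nM, with a range from 15 nM to 500 nM.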

Compound 4, half-maximal inhibitory concentration: > 10000 nM
Compound 4: a limit, no number; the forecaster's own chance of this, stated with the estimate: 5%; middle value at least 120-fold (2.09 log units) from the limit.
By their numbers in this assay, from the lowest: compounds 1, 2 and 3 (each within the scatter of the next, the first and the last beyond it). At a limit, above all of these: compound 4.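

In this assay compound 4 gives > 10000 nM, which is a limit of the assay and not a number. Phenyl in place of methyl on the amine nitrogen in the ring gives an at least 1000-fold higher number from compound 1 to compound 4 (3.00 log units; beyond the scatter), whereas the largest change on the chain at the aromatic nitrogen gives only a 2.6-fold higher number from compound 1 to compound 3 (0.41 log units; beyond the scatter). Compounds 1, 2 and 3 all carry the methyl and so said nothing about this position, which compound 4 now shows to be far less tolerant of change than the chain, at least for phenyl.

The compounds shown leave open whether a small group such as hydrogen or ethyl on this nitrogen would be tolerated, or whether a benzyl group would behave like phenyl. Going by these compounds, it also remains open whether phenyl has the same effect with the hexyl chain of compound 3.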